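Exchanging the pentahydroxyhexyl group of compound 2

The compounds below may be only part of what the source reports. "The series", "measured", "known", "first", "only" and "open" are said of these compounds alone.

Compound 1 `CC[C@H](C)[C@@H](O)C(=O)O[C@@H](C(=O)O[C@@H](C(=O)O[C@@H](C(=O)O[C@@H](C(=O)O[C@H](CO)[C@@H](O)[C@H](O)[C@H](O)CO)[C@@H](C)CC)[C@@H](C)CC)[C@@H](C)CC)[C@@H](C)CC`: 36200 nM
Compound 2 `CC[C@H](C)[C@@H](O)C(=O)O[C@@H](C(=O)O[C@@H](C(=O)O[C@@H](C(=O)O[C@@H](C(=O)OC[C@@H](O)[C@@H](O)[C@H](O)[C@H](O)CO)[C@@H](C)CC)[C@@H](C)CC)[C@@H](C)CC)[C@@H](C)CC`: > 53200 nM (a limit)

Both compounds were tested in a functional assay on HepG2 cells (Homo sapiens) for cytotoxicity, read by MTT assay, with a stated time of 24 h; a lower number here means a stronger inhibitor, a higher number a weaker inhibitor. Compound 2 stands at > 53200 nM, which is a limit of the assay and not a number. The next structure is compound 3 `CC[C@H](C)[C@@H](O)C(=O)O[C@@H](C(=O)O[C@@H](C(=O)O[C@@H](C(=O)O[C@@H](C(=O)O[C@H](CO)[C@@H](O)[C@H](O)CO)[C@@H](C)CC)[C@@H](C)CC)[C@@H](C)CC)[C@@H](C)CC`, which carries 2,3,4-trihydroxy-1-(hydroxymethyl)butyl in place of 2,3,4,5,6-pentahydroxyhexyl on an oxygen next to a carbonyl group.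

Going by the values given here, one measured step bears on this change: an at least 1.4-fold higher number from compound 1 to compound 2 (0.16 log units; that floor lies within the scatter). There, 2,3,4,5,6-pentahydroxyhexyl entered in place of 2,3,4,5-tetrahydroxy-1-(hydroxymethyl)pentyl at the same place. That step is only a floor, and it lies within the scatter. The group of compound 3 has the same 1-(hydroxymethyl) form as the group of compound 1, which gives 36200 nM, so a value near that of compound 1 is expected in this assay. No step beyond the scatter is expected, and any movement should be towards a lower number. The estimated change is an at least 1.2-fold lower number from compound 2 to compound 3 (0.10 log units; that floor lies within the scatter). Compound 3 is estimated at 42000 nM, with an expected range from 22000 nM to 62000 nM.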

Compound 3, half-maximal inhibitory concentration: 26200 nM
For compound 3 the middle estimate is 1.6-fold (0.20 log units) above the measured one, within the range that was stated.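

In this assay, going by these compounds alone, the shortening of the polyhydroxy group on the oxygen next to the carbonyl group can now be read between two real numbers for the first time: hydrogen in place of hydroxymethyl gives a 1.4-fold lower number from compound 1 to compound 3 (0.14 log units; within the scatter), so within the 1-(hydroxymethyl) form this change leaves no step that can be told from the scatter. The exchange of 2,3,4,5,6-pentahydroxyhexyl for 2,3,4-trihydroxy-1-(hydroxymethyl)butyl gives an at least 2.0-fold lower number from compound 2 to compound 3 (0.30 log units; that floor lies within the scatter), and this floor too does not clear the scatter. The true size of that step cannot be read, because compound 2 stands at a limit of the assay and not at a number: the limit of > 53200 nM in this assay, at which 1 of the 3 values shown sits.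

The compounds shown leave open whether the straight pentahydroxyhexyl form truly parts from the branched 1-(hydroxymethyl) form, since only a floor separates them so far. They also leave open how far this position tolerates a departure from polyhydroxy chains, for instance a plain ethyl group, an amine or a carboxylic acid on the same oxygen, which would say more than further changes in the count of hydroxyl groups.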